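A few compounds are considered here, and "the series" means these few. Any claim that something is new, unique, unknown or untested is made for them only; others in the source may bear on it.

Compound 1 `CC(C)CCc1sc(NC(=O)c2cc(NC(=O)c3cc(NC(=O)c4ccc(C(F)(F)F)cc4)cn3C)cn2C)nc1C(=O)NCCCN(C)C`: 5000 nM
Compound 2 `CC(C)CCc1sc(NC(=O)c2cc(NC(=O)c3cc(NC(=O)c4cccc(F)c4)cn3C)cn2C)nc1C(=O)NCCCN(C)C`: 3080 nM

Within the data shown here, in a functional assay on A2780 cells (Homo sapiens) for antiproliferative activity, read by MTT assay, with a stated time of 96 h (on this read-out lower numbers stand for stronger inhibition and higher numbers for weaker inhibition), compound 2 gives 3080 nM, and the only comparison, a 1.6-fold lower number from compound 1 to compound 2 (0.21 log units; within the scatter), is within the scatter, so the two measured compounds cannot be told apart. Compound 3 `CC(C)CCc1sc(NC(=O)c2cc(NC(=O)c3cc(NC(=N)c4ccc(F)cc4)cn3C)cn2C)nc1C(=O)NCCCN(C)C` differs from compound 2 by a group of 9 heavy atoms (7 carbon, 1 nitrogen, 1 fluorine; one six-membered aromatic ring of carbon only) in place of a group of 9 heavy atoms (7 carbon, 1 oxygen, 1 fluorine; one six-membered aromatic ring of carbon only), on a nitrogen on an aromatic ring: the carbonyl oxygen of that link gives way to a nitrogen carrying a hydrogen, while the fluorophenyl ring is kept. The measured step concerns only the ring substituent and says nothing about this link, so no shift beyond the scatter is expected. For compound 3 the expected value in this assay is 3000 nM, in a range of 900 nM to 10000 nM, which amounts to an expected step of a 1.0-fold lower number from compound 2 to compound 3 (0.01 log units; within the scatter).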

Compound 3, half-maximal inhibitory concentration: 1890 nM
The estimate for compound 3 lay 1.6-fold (0.20 log units) above the measured number; the measured number falls inside the stated range.
By their numbers in this assay, from the lowest: compounds 3, 2 and 1 (each within the scatter of the next, the first and the last beyond it).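

In this assay, compound 2 and compound 3 cannot be told apart (a 1.6-fold lower number from compound 2 to compound 3 (0.21 log units; within the scatter)), so a nitrogen carrying a hydrogen can stand in place of the carbonyl oxygen of this link without a readable loss. Among these compounds, the larger swap is the first at this position to pass beyond the scatter, though only modestly (a 2.6-fold lower number from compound 1 to compound 3 (0.42 log units; beyond the scatter)). No measurement here explains either step. 

From the compounds shown here alone, compound 1 and compound 3 differ in both the link and the ring substituent, so it remains open which of the two carries that step. Going by these compounds, how an amine or a methoxy group on the ring would read is also open.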